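Bromo on the Phenyl Arm: What to Expect for Compound 3

The source may report more compounds than this note shows. Statements on the series, on what has been measured and on what is new or still open speak of the compounds shown alone.

Measured so far:
compound 1 `O=C(CCCCC1CCSS1)NCc1cn(CCCCCOc2ccc3ccc(=O)oc3c2)nn1` — 84.9%
compound 2 `O=C(CCCCC1CCSS1)NCc1cn(CCCCCOc2ccc3cc(-c4ccccc4)c(=O)oc3c2)nn1` — 17.7%

In a functional assay on PC-12 cells (Rattus norvegicus) for cytotoxicity, read by MTT assay, with stated times of 3 h and 2 h, tested at 50 uM (a lower number here means a weaker effect, a higher number a stronger effect of the compound at the concentration tested), compound 1 gives 84.9%, while compound 2 gives 17.7%. Going by the values given here, the one step between them, a number 67.2 percentage points lower from compound 1 to compound 2 (beyond the scatter), is the only comparison available, and it leaves compound 2 as the lower of the two numbers, with compound 1 standing far higher.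

Compound 3 `O=C(CCCCC1CCSS1)NCc1cn(CCCCCOc2ccc3cc(-c4ccc(Br)cc4)c(=O)oc3c2)nn1` differs from compound 2 by bromo in place of hydrogen on an aromatic carbon, the bromine sitting on the six-membered aromatic ring of carbon only, para to a large group. Among the compounds with values here, no measured step touches a change on that ring: the step from compound 1 to compound 2 concerns adding the phenyl itself, not decorating it. On this basis the step of a number 2.3 percentage points higher from compound 2 to compound 3 (within the scatter) is expected to stay within the scatter, with no clear direction. Compound 3 is therefore estimated at 20%, in the range 5% to 45%.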

Compound 3, a percentage reported as activity, at one concentration (the size of the read-out at that concentration, not a potency): 53.6%
Estimate against measurement, compound 3: 33.6 percentage points below; the whole stated range lies below it.
By their numbers in this assay, from the lowest: compound 2; then compound 3; then compound 1.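

In this assay the phenyl arm proves highly responsive to substitution: bromo in place of hydrogen on an aromatic carbon, para to a large group, gives a number 35.9 percentage points higher from compound 2 to compound 3 (beyond the scatter) and so shows what the earlier pair could not, that a single substituent on this ring can shift the read-out strongly. The 4-bromophenyl arm recovers only part of the loss that came with the phenyl, since there remains a number 31.3 percentage points lower from compound 1 to compound 3 (beyond the scatter) in the same assay. Nothing available accounts for this rise.

Going by these compounds, whether the shift belongs to bromine in particular or would also follow from another group at this place remains open, for instance chloro, methoxy or an amine. On these data alone, it also remains open whether bromo elsewhere on the same ring would give a similar number.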